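Swapping the aryl group on sulfur in compound 1

This account rests on a few compounds, and the source may have more. Where it says the series, first, only, none or still open, it means among the compounds named here.

Within the data shown here, in a functional assay on SMMC-7721 cells (Homo sapiens) for inhibition, read by CCK-8 assay, with a stated time of 72 h, tested at 2 uM (on this read-out lower numbers stand for less inhibition of growth and higher numbers for more inhibition of growth at the one concentration tested), three compounds sharing one core have numbers so far. Compound 1 (`Nc1ccccc1NC(=O)c1ccc(CSc2cccc(F)c2)cc1`) gives 18.6%. Compound 3 (`Nc1ccccc1NC(=O)c1ccc(CSc2ccc(C(F)(F)F)cn2)cc1`) gives 12.4%, within the scatter of compound 1. Compound 2 (`Nc1ccccc1NC(=O)c1ccc(CSc2nccc(C(F)(F)F)n2)cc1`) gives 66.1%, beyond the scatter from both of the others. Compound 1 therefore stands level with compound 3 and far short of compound 2.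

The next compound to be read is compound 4 (`Nc1ccccc1NC(=O)c1ccc(CSc2ccc(Cl)cc2)cc1`). Its change from compound 1 is 4-chlorophenyl in place of 3-fluorophenyl on a sulfur. Among the measured compounds shown here, no pair of measured compounds differs in one place only, so the data offer no direct precedent for this swap. Compound 4 keeps a six-membered aromatic ring of carbon only on the sulfur, and among the measured compounds only compound 1, at 18.6%, has such a ring. The high number of compound 2 comes with a different group and is not carried over, although it leaves some room upward. The expected step, a number 3.4 percentage points higher from compound 1 to compound 4 (within the scatter), stays within the scatter, with no firm direction. For compound 4 the estimated value is 22%, with an expected range from 8% to 45%.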

Compound 4, percent growth inhibition at one concentration: 2.93%
The estimate for compound 4 lay 19.1 percentage points above the measured number; the measured number lies below the stated range.
By their numbers in this assay, from the lowest: compounds 4, 3 and 1 (each within the scatter of the next, the first and the last beyond it); then compound 2.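

Among these compounds, this is the first pair that differs in one place only: in this assay the swap to 4-chlorophenyl in place of 3-fluorophenyl on a sulfur is a step of a number 15.7 percentage points lower from compound 1 to compound 4 (beyond the scatter) and so exceeds the usual scatter. The position therefore responds to a change of halogen and its place on a six-membered aromatic ring of carbon only, even when the ring stays the same kind and the two groups match in heavy-atom count, hydrogen-bond donors, hydrogen-bond acceptors and net charge. No measured property of either group is available to account for this step.

Among the compounds shown here, the single step joins two changes, so it cannot say whether the halogen or its place on the ring matters; 3-chlorophenyl or 4-fluorophenyl on the same sulfur would separate them. For the compounds shown here, also open is how plain phenyl, or a ring carrying an amine or a carboxylic acid, would read here, and no one-place pair yet connects compound 2 to the rest of the series.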